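The source may hold more compounds than are shown below. What is called first, only, known or untested is meant among the compounds shown, and "the series" means these compounds.

Working notes on the amide series that shares the core of compound 1 `CN(c1ccc2cc(NC(=O)CCc3ccc(C(F)(F)F)cc3)ccc2n1)C1CCCCC1`. In an assay on isolated protein for displacement of a labelled ligand from melanin-concentrating hormone receptor 1 (Homo sapiens) (a higher number here means a weaker inhibitor, a lower number a stronger inhibitor), compound 1 gives 18 nM. Compound 2 `CC(C)C(=O)NC1CCN(c2ccc3cc(NC(=O)CCc4ccc(C(F)(F)F)cc4)ccc3n2)C1` gives 1 nM in this assay, and compound 3 `CCN(CC)c1ccc2cc(NC(=O)CCc3ccc(C(F)(F)F)cc3)ccc2n1` gives 88 nM. Compound 3 therefore stands highest of the three numbers: the step of a 4.9-fold higher number from compound 1 to compound 3 (0.69 log units; beyond the scatter) separates it from the nearest compound, and the step of an 88-fold higher number from compound 2 to compound 3 (1.94 log units; beyond the scatter) from the furthest.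

Compound 4 `O=C(CCc1ccc(C(F)(F)F)cc1)Nc1ccc2nc(N3CC4CCC3C4)ccc2c1` remains to be measured in this assay. Relative to compound 3 the change is a group of 7 heavy atoms (6 carbon, 1 nitrogen; one five-membered non-aromatic ring of carbon only, one five-membered non-aromatic ring with 1 hetero atom) in place of a group of 5 heavy atoms (4 carbon, 1 nitrogen; no ring), on an aromatic carbon. Going by the values given here, the steps that bear on it are those at the same aromatic carbon: a 4.9-fold higher number from compound 1 to compound 3 (0.69 log units; beyond the scatter) shows that the no-ring diethylamino group sits above a ring-bearing group, and an 18-fold lower number from compound 1 to compound 2 (1.26 log units; beyond the scatter) shows how far a second ring-bearing group goes beyond that. A ring-bearing group entering in place of diethylamino is thus expected to lower the number, most plausibly toward the region of compound 1, whose value is 18 nM. The expected step is a 5.9-fold lower number from compound 3 to compound 4 (0.77 log units; beyond the scatter). Compound 4 is estimated at 15 nM, with a range from 4 nM to 60 nM.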

Compound 4, half-maximal inhibitory concentration: 1 nM
For compound 4 the middle estimate is 15-fold (1.18 log units) above the measured one, and the stated range ends above it.
By their numbers in this assay, from the lowest: compounds 2 and 4 (each within the scatter of the next); then compound 1; then compound 3.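

In this assay, at this aromatic carbon next to the ring nitrogen, the group with two five-membered non-aromatic rings gives an 88-fold lower number from compound 3 to compound 4 (1.94 log units; beyond the scatter) in place of diethylamino, and an 18-fold lower number from compound 1 to compound 4 (1.26 log units; beyond the scatter) in place of cyclohexyl(methyl)amino. Against 3-((isopropylcarbonyl)amino)pyrrolidin-1-yl the result is no change at the digits printed from compound 2 to compound 4 (within the scatter), so the carbonyl and amide hydrogen of that group are not required to reach this value. All three ring-bearing groups give lower numbers than diethylamino, yet compound 1 remains apart from compound 2 and compound 4, so the presence of a ring alone does not set the value.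

Open, going by these compounds, is whether a single-ring group such as pyrrolidin-1-yl, piperidin-1-yl or morpholin-4-yl at this position would match compound 4. No measurement at hand accounts for these steps.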